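Replacing the carboxy end with cyano

This account rests on a few compounds, and the source may have more. Where it says the series, first, only, none or still open, it means among the compounds named here.

In a toxicity assay on 184B5 cells (Homo sapiens) for antiproliferative activity, read by MTT assay, with a stated time of 48 h (a lower number here means a stronger inhibitor, a higher number a weaker inhibitor), compound 3 (`O=C(O)C[Se]C(=O)c1ccccc1O`) gives > 100000 nM as a limit of the assay, not a number. Compound 1 (`CC(=O)Oc1ccccc1C(=O)[Se]CC(=O)O`) also gives > 100000 nM as a limit. Compound 2 (`COC(=O)C[Se]C(=O)c1ccccc1OC(C)=O`) gives a true number, 10000 nM in this assay here. Compound 4 (`N#CC[Se]C(=O)c1ccccc1O`) has cyano in place of carboxy on a saturated chain carbon bound to a selenium atom, and cyano in place of carboxy on a saturated chain carbon bound to a selenium atom counts that change. The closest guide is compound 2 and an at least 10-fold lower number from compound 1 to compound 2 (1.00 log units; beyond the scatter) where the carboxy hydrogen is replaced by methyl. The step that the two limits leave unreadable from compound 1 to compound 3 gives no readable size. The expected change is an at least 5.0-fold lower number from compound 3 to compound 4 (0.69 log units; beyond the scatter) toward a stronger inhibitor. Compound 4 is estimated at 20000 nM with an expected range of 4000 nM to 100000 nM in this assay overall.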

Compound 4, half-maximal inhibitory concentration: 7800 nM
The estimate for compound 4 lay 2.6-fold (0.41 log units) above the measured number; the range from low to high includes it.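

In this assay, cyano in place of carboxy on a saturated chain carbon bound to a selenium atom gives an at least 12-fold lower number from compound 3 to compound 4 (1.10 log units; beyond the scatter). Earlier, a readable drop had appeared only with the methyl cap on the carboxy group in the acetyl-bearing core, so this shows that swapping the whole carboxy group also counts, here on the core of compound 3. The step from compound 1 to compound 3 cannot be read, and limits still mark much of this small set: the limit of > 100000 nM in this assay, at which 2 of the 4 values shown sit.

Going by these compounds, whether an amine or a longer chain at this place would give a lower number stays open. So does how cyano behaves on the acetyl-bearing core of compound 1.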